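Plasma half-life expected for compound 3

The compounds below may be only part of what the source reports. "The series", "measured", "known", "first", "only" and "open" are said of these compounds alone.

In an ADME assay on a cell-free system (plasma, Homo sapiens) for metabolic stability, at 37 degrees C (a lower number here means that the compound disappears faster, a higher number that the compound lasts longer), compound 1 (`CCC/N=C1\S/C(=C\c2ccc(C(=O)OC)c(Cl)c2)C(=O)N1c1ccccc1C`) gives > 3 h as a limit of the assay, not a number. Compound 2 (`CCC/N=C1\S/C(=C\c2ccc(C(=O)OCCCO)cc2)C(=O)N1c1ccccc1O`) gives > 3 h as a limit too. Among the measured compounds shown here, compound 2 therefore stands at the limit (the limit of > 3 h in this assay, at which 2 of the 2 values shown sit), and no measured step is available for sizing a change. Compound 3 (`CCC/N=C1\S/C(=C\c2ccc(C(=O)OCc3oc(=O)oc3C)cc2)C(=O)N1c1ccccc1O`) differs from compound 2 in one place (a group of 7 heavy atoms (4 carbon, 3 oxygen; one five-membered aromatic ring with 2 hetero atoms) in place of a group of 3 heavy atoms (2 carbon, 1 oxygen; no ring), on a saturated chain carbon bound to an oxygen next to a carbonyl group), with the change on a saturated chain carbon bound to an oxygen next to a carbonyl group. A clear fall in half-life, beyond the usual scatter, is expected here, although neither measured compound offers a precedent for it. The expected size of the change is an at least 6.0-fold lower number from compound 2 to compound 3 (0.77 log units; beyond the scatter) as a working estimate. In this assay the estimated half-life for compound 3 is 0.5 h (expected range 0.1 h to 2 h).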

Compound 3, half-life in the Homo sapiens assay: 0.15 h
For compound 3 the middle estimate is 3.3-fold (0.52 log units) above the measured one, and the stated range covers the measured number.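

In the Homo sapiens assay the change on a saturated chain carbon bound to an oxygen next to a carbonyl group gives an at least 20-fold lower number from compound 2 to compound 3 (1.30 log units; beyond the scatter), and compound 3 is the only one of the three with a number rather than a limit. Compound 2 gives > 3 h, which is a limit, so this position can separate the series in this read-out even though the values for compounds 1 and 2 could not. In a physicochemical assay for solubility, read by nephelometry, measured as kinetic solubility (on this read-out higher numbers stand for higher solubility and lower numbers for lower solubility), compound 2 gives 183000 nM and compound 3 gives 79000 nM. The same replacement of 2-hydroxyethyl also changes the reading in the physicochemical assay: the measured solubility of compound 2, 183000 nM, and of compound 3, 79000 nM, a 2.3-fold lower number (0.36 log units; beyond the scatter)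

A single replacement cannot show whether the fall in half-life belongs to the entering ring group or follows the loss of 2-hydroxyethyl. A benzyl group, a longer chain or a carboxylic acid on the same carbon would be needed to separate the two.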